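Trimming the Ester Side Chain of Compound 1

The source may hold more compounds than are shown below. What is called first, only, known or untested is meant among the compounds shown, and "the series" means these compounds.

Compound 1 `COC(=O)COc1cccc(/C=C/c2ccc3ccccc3n2)c1` stands at the weak end of the three numbers in hand: in a functional assay on lung (Cavia porcellus) for binding affinity to cysteinyl leukotriene receptor (Homo sapiens) (on this read-out lower numbers stand for stronger inhibition and higher numbers for weaker inhibition), compound 1 gives 1000 nM. Compound 3 `O=C(O)CCCOc1cccc(/C=C/c2ccc3ccc(Cl)cc3n2)c1` gives 39 nM in this assay, and compound 2 `O=C(O)CCSC(SCCC(=O)O)c1cccc(/C=C/c2ccc3ccc(Cl)cc3n2)c1` gives 3 nM; both lie beyond the scatter below compound 1. The unmeasured compound 4 `Oc1cccc(/C=C/c2ccc3ccccc3n2)c1` differs from compound 1 by hydrogen in place of (methoxycarbonyl)methyl on an oxygen on an aromatic ring, so the side chain is cut back to a bare hydroxy. Within the data shown here, no measured pair isolates this change. The two stronger binders, compound 2 and compound 3, each carry an acid on the side chain and a chloro on the core, and compound 4 carries neither. The expected step is a 2.0-fold higher number from compound 1 to compound 4 (0.30 log units; within the scatter), small and, if anything, toward a higher number. Compound 4 is expected to give about 2000 nM in this assay, within 500 nM to 10000 nM.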

Compound 4, half-maximal inhibitory concentration: 560 nM
Estimate against measurement, compound 4: 3.6-fold (0.55 log units) above; the measured number falls inside the stated range.
By their numbers in this assay, from the lowest: compound 2; then compound 3; then compounds 4 and 1 (each within the scatter of the next).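

In this assay, cutting (methoxycarbonyl)methoxy back to hydroxy gives a 1.8-fold lower number from compound 1 to compound 4 (0.25 log units; within the scatter), so this first single-place change on the core of compound 1 leaves the number within the scatter. The 5 heavy atoms of the (methoxycarbonyl)methyl group can thus leave this oxygen on an aromatic ring with no readable change in this read-out. No measurement at hand offers an explanation for this result. On these data alone, whether a carboxylic acid or an amine-bearing chain on this oxygen of the core of compound 1 would move the number remains open.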